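The source may report more compounds than this note shows. Statements on the series, on what has been measured and on what is new or still open speak of the compounds shown alone.

Working notes on the series:

- compound 1 `CC[C@H](c1ccc(O)cc1)[C@@H](CC)c1ccc(OCC(O)CCl)cc1`: 0.5 h
- compound 2 `CC[C@H](c1ccc(O)cc1)[C@@H](CC)c1ccc(C(=O)CBr)cc1`: < 0.5 h, a limit and not a number
- compound 3 `CC[C@H](c1ccc(O)cc1)[C@@H](CC)c1ccc(OCC(=O)CCl)cc1`: 0.25 h
- compound 4 `CC[C@H](c1ccc(O)cc1)[C@@H](CC)c1ccc(OCC(=O)CBr)cc1`: not yet measured

In an ADME assay for pharmacokinetics (on this read-out higher numbers stand for a longer-lived compound and lower numbers for a shorter-lived compound), compound 1 gives 0.5 h. Within the data shown here, the only other number lies within the scatter of it: compound 3 gives 0.25 h. The reading for compound 2 is a limit, < 0.5 h.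

Compound 4 differs from compound 1 as follows: (bromomethyl)carbonyl in place of 2-chloro-1-hydroxyethyl on a saturated chain carbon bound to an oxygen on an aromatic ring. Cut one bond further out, this is 3-chloro-2-hydroxypropoxy replaced by ((bromomethyl)carbonyl)methoxy.

The closest guide is a 2.0-fold lower number from compound 1 to compound 3 (0.30 log units; within the scatter), a change at the same place that brings in (chloromethyl)carbonyl, and it stays within the scatter. The step of a number no higher from compound 1 to compound 2 (the limit leaves the size open) brings in (bromomethyl)carbonyl, but on an aromatic carbon, and its size cannot be read. The step that the limit leaves unreadable from compound 2 to compound 3 is also unreadable, so the data give no measured comparison of the bromomethyl and chloromethyl groups at the place in question.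

Resting mainly on a 2.0-fold lower number from compound 1 to compound 3 (0.30 log units; within the scatter), a small downward move is expected in this assay, not clearly beyond the scatter. The expected step is a 2.0-fold lower number from compound 1 to compound 4 (0.30 log units; within the scatter). A report as a limit alone is also possible. For compound 4 the estimate is 0.25 h, with an expected range of 0.12 h to 0.5 h.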

Compound 4, half-life: < 0.5 h
Compound 4: only a limit was reported; the forecaster's own chance of this, stated with the estimate: 40%; the middle value does not contradict the limit.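

In this assay compound 4 gives < 0.5 h, which is a limit and not a number. This shows that ((bromomethyl)carbonyl)methoxy in place of 3-chloro-2-hydroxypropoxy also ends in a limit, with a number no higher from compound 1 to compound 4 (the limit leaves the size open) as its step, but the steps from compounds 1, 2 and 3 to compound 4 cannot be read, including bromo in place of chloro on a saturated chain carbon bound to a carbonyl carbon. Compound 4 therefore shares its reported limit with compound 2: the limit of < 0.5 h in this assay, at which 2 of the 4 values shown sit.

As far as these compounds go, the size of the change from chloro to bromo at this position remains open, as there is still no numerical comparison of the two. Also open, from the compounds shown here alone, is how this read-out would respond to an amine or a carboxylic acid in place of the halogen on the saturated chain carbon bound to a carbonyl carbon.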